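A few compounds are considered here, and "the series" means these few. Any claim that something is new, unique, unknown or untested is made for them only; others in the source may bear on it.

Measured so far in a functional assay on DU-145 cells (Homo sapiens) for inhibition, read by trypan blue exclusion, with a stated time of 96 h; a lower number here means a stronger inhibitor of growth, a higher number a weaker inhibitor of growth:
compound 1, `O=C(/C(=C\c1ccc(Br)cc1)Sc1ccc(Br)cc1)c1ccc(Br)cc1`: 1000 nM
compound 2, `O=C(/C(=C\c1ccc(F)cc1F)Sc1ccc(Br)cc1)c1ccc(Br)cc1`: 1000 nM
compound 3, `Cc1ccc(S(=O)(=O)/C(=C/c2ccc(Br)cc2)C(=O)c2ccc(Br)cc2)cc1`: 10000 nM

Compound 2 differs from compound 1 by 2,4-difluorophenyl in place of 4-bromophenyl on a double-bonded chain carbon bound to a double-bonded chain carbon, and in this assay no change at the digits printed from compound 1 to compound 2 (within the scatter). Compound 3 rests on another core; how the core of compound 3 differs from that of compound 1 is not broken down here, and in this assay compound 3 gives 10000 nM, a number well beyond the scatter above both compound 1 and compound 2.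

Compound 4, `Cc1ccc(S(=O)(=O)/C(=C/c2ccc(F)cc2F)C(=O)c2ccc(Br)cc2)cc1`, is not yet measured. It differs from compound 3 by 2,4-difluorophenyl in place of 4-bromophenyl on a double-bonded chain carbon bound to a double-bonded chain carbon, the same change as that from compound 1 to compound 2. In this assay the expected step is no change at the digits printed from compound 3 to compound 4 (within the scatter), because no change at the digits printed from compound 1 to compound 2 (within the scatter) showed no movement for the same change on the other core. Compound 4 is therefore estimated at 10000 nM in this assay, with an expected range from 4000 nM to 25000 nM.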

Compound 4, concentration for 50% growth inhibition: > 100000 nM
Compound 4 was reported as a limit (the forecaster's own chance of this, stated with the estimate: 20%); at least 10-fold (1.00 log units) between middle value and limit.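

Carrying 2,4-difluorophenyl in place of 4-bromophenyl from one core to the other does not hold in this assay; on the core of compound 3 the change gives an at least 10-fold higher number from compound 3 to compound 4 (1.00 log units; beyond the scatter), and the two steps part: the same change on two cores in this assay, no change at the digits printed (within the scatter) from compound 1 to compound 2 and an at least 10-fold higher number (1.00 log units; beyond the scatter) from compound 3 to compound 4, at least 10-fold (1.00 log units) apart, beyond the scatter of two such steps

Compound 4 gives > 100000 nM, which is a limit and not a number. The result shows that the step seen on the core of compound 1 cannot be assumed on the core of compound 3, but it fixes neither the full size of the step nor any rule for other changes.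

Still open, going by these compounds, is whether other groups at the same place, such as a 4-methoxyphenyl, a 4-aminophenyl or a 4-carboxyphenyl, also behave differently on the two cores.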